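The source may hold more compounds than are shown below. What is called first, only, known or untested is meant among the compounds shown, and "the series" means these compounds.

The compounds here share one core, and the change from compound 2 to compound 3 rearranges the atoms of a short chain without adding or removing any. Compound 1 `Cc1nc(Nc2ccc(F)cc2)c2cc[nH]c2n1` carries a larger attachment on the same core. In a functional assay on the whole organism for inhibition, with Nicotiana tabacum as the target (on this read-out lower numbers stand for stronger inhibition and higher numbers for weaker inhibition), compound 1 gives 372000000 nM. Compound 2 `CCCNc1[nH]c(C)nc2nccc1-2` carries a propylamino group, and in this assay compound 2 gives 339000000 nM. These two numbers lie within the usual scatter of each other, so the data show no real difference between compound 1 and compound 2 in this assay; neither can be called the more potent.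

Compound 3 `Cc1nc2nccc-2c(NC(C)C)[nH]1` has not yet been measured. It differs from compound 2 in a single place: isopropyl in place of propyl on a nitrogen on an aromatic ring. The two compounds contain the same atoms, joined differently. Within the data shown here, no measured pair shows what this kind of rearrangement does in this assay, so the expectation rests on the small size of the change alone. The step from compound 2 to compound 3 is expected to be no change at the digits printed from compound 2 to compound 3 (within the scatter), meaning no change beyond the scatter in either direction. Compound 3 is therefore estimated at 339000000 nM in this assay, with a range from 150000000 nM to 800000000 nM.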

Compound 3, half-maximal inhibitory concentration: 550000000 nM
Compound 3: the middle estimate sits 1.6-fold (0.21 log units) below what was measured; measured number inside the range.
By their numbers in this assay, from the lowest: compounds 2, 1 and 3 (each within the scatter of the next).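

Replacing propyl with isopropyl on a nitrogen on an aromatic ring gives a 1.6-fold higher number from compound 2 to compound 3 (0.21 log units; within the scatter) in this assay, so this rearrangement of the same carbon atoms produces no real difference on this read-out. Among these compounds, compound 1 and compound 2 did not form a one-place pair, which makes this the first direct comparison at this position, and it shows that this position tolerates the change from a straight chain to a branched one without a shift beyond the usual variation between repeats. Nothing available explains this result, and a step within the scatter leaves little to explain in any case.

On these data alone, this single pair tests only two arrangements of the chain, so it remains open whether a longer chain such as butyl or hexyl, a ring such as cyclopropyl or cyclohexyl, or a chain ending in an amine or a carboxylic acid would move the number beyond the scatter. It also leaves open whether replacing the hydrogen on this same nitrogen with a methyl group would have any effect on the read-out.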